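The source may hold more compounds than are shown below. What is called first, only, known or untested is meant among the compounds shown, and "the series" means these compounds.

Compound 1 `CCCCCCCCCCCC[C@@H](O)[C@H]1CC[C@H]([C@H](O)CCCCCCCCCCNC(=O)c2ccsc2)O1` carries a long chain ending in an amide, and in a functional assay on MDA-MB-231 cells (Homo sapiens) for inhibition, read by colorimetric assay and sulforhodamine B assay, with a stated time of 48 h (on this read-out higher numbers stand for weaker inhibition of growth and lower numbers for stronger inhibition of growth), compound 1 gives 4470 nM. Compound 2 `CCCCCCCCCCCC[C@@H](O)[C@H]1CC[C@H]([C@H](O)CCCCCCCCCCNC(=O)c2ccnn2C)O1` bears a different ring on the same carbonyl carbon; in this assay compound 2 gives 8510 nM. Compound 1 sits at the lower end of these two numbers, yet the step of a 1.9-fold higher number from compound 1 to compound 2 (0.28 log units; within the scatter) is within the scatter, so the two are not told apart. Compound 3 `CCCCCCCCCCCC[C@@H](O)[C@H]1CC[C@H]([C@H](O)CCCCCCCCCCNC(=O)c2ccoc2)O1` differs from compound 1 by furan-3-yl in place of thiophen-3-yl on a carbonyl carbon. Among the compounds with values here, only one measured step bears on this change, the ring swap on the carbonyl carbon, a 1.9-fold higher number from compound 1 to compound 2 (0.28 log units; within the scatter), which stayed within the scatter. Because that step a 1.9-fold higher number from compound 1 to compound 2 (0.28 log units; within the scatter) was within the scatter, no step beyond the scatter is expected here either. Compound 3 is therefore estimated at 5000 nM, with a range from 2500 nM to 10000 nM. The expected step of a 1.1-fold higher number from compound 1 to compound 3 (0.05 log units; within the scatter) reflects this.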

Compound 3, concentration for 50% growth inhibition: 100000 nM
For compound 3 the middle estimate is 20-fold (1.30 log units) below the measured one, outside the stated range (above it).
By their numbers in this assay, from the lowest: compounds 1 and 2 (each within the scatter of the next); then compound 3.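

In this assay the ring on the carbonyl carbon proves able to change the read-out sharply: a 22-fold higher number from compound 1 to compound 3 (1.35 log units; beyond the scatter), and a 12-fold higher number from compound 2 to compound 3 (1.07 log units; beyond the scatter), both beyond the scatter, whereas the earlier ring swap stayed within it. The change from thiophen-3-yl to furan-3-yl is small on paper, as both are five-membered aromatic rings with one hetero atom and differ only in sulfur against oxygen, so a similar ring count and size does not guarantee a similar result at this position. Nothing available here explains why this swap weakens growth inhibition so strongly.

On these data alone, it remains open whether the weak result belongs to furan-3-yl alone or would also appear with furan-2-yl or a phenyl ring on the same carbonyl carbon. As far as these compounds go, it is also open whether furan-3-yl would give the same result on a shorter chain.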